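The source may report more compounds than this note shows. Statements on the series, on what has been measured and on what is new or still open speak of the compounds shown alone.

Compound 2 `O=C(/C=C/c1ccccc1Cl)c1ccc(OCc2ccccc2)cc1` gives the higher of the two numbers available here: in a functional assay on HCT-116 cells (Homo sapiens) for antiproliferative activity, read by sulforhodamine B assay, with a stated time of 3 days, tested at 25 uM (on this read-out higher numbers stand for a stronger effect at the one concentration tested and lower numbers for a weaker effect), compound 2 reaches 54.5%, while compound 1 `Cc1ccc(COc2ccc(C(=O)/C=C/c3ccc(Cl)cc3)cc2)cc1` gives 12.3%, a gap beyond the usual scatter of such measurements. Compound 3 `COc1cccc(/C=C/C(=O)c2ccc(OCc3ccccc3)cc2)c1` has not yet been tested. It differs from compound 2 in one place: 3-methoxyphenyl in place of 2-chlorophenyl on a double-bonded chain carbon bound to a double-bonded chain carbon. Among the compounds with values here, no measured pair shows what such a swap does to the read-out. The step of a number 19.5 percentage points lower from compound 2 to compound 3 (beyond the scatter) implied by the estimate is expected to be a moderate decrease. For compound 3 the expected result in this assay is 35%, within a range from 10% to 65%.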

Compound 3, a percentage reported as inhibition, at one concentration (the size of the read-out at that concentration, not a potency): 35.4%
Beside the measured number, compound 3's estimate is 0.4 percentage points below it; the measured number falls inside the stated range.
By their numbers in this assay, from the lowest: compound 1; then compound 3; then compound 2.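

Swapping 2-chlorophenyl for 3-methoxyphenyl gives a number 19.1 percentage points lower from compound 2 to compound 3 (beyond the scatter) in this assay. Within the data shown here, this is the first single-place comparison here, and it shows that the group on a double-bonded chain carbon bound to a double-bonded chain carbon affects this read-out. No measurement here explains the step. Going by these compounds, the swap changes both the group on the ring and its ring position, so the contribution of each remains open. A 3-chlorophenyl or 2-methoxyphenyl group at this place would separate the two, while an aminophenyl group would test a different kind of group.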